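The source may report more compounds than this note shows. Statements on the series, on what has been measured and on what is new or still open speak of the compounds shown alone.

Measured compounds:
compound 1 `COc1ccc(OCCCOc2cc(=O)n(CCCO)c3c2CC(C/C=C(\C)CCC=C(C)C)C(C)(C)C3)cc1`, giving 0% in a functional assay on PANC-1 cells (Homo sapiens) for inhibition, read by MTT assay, with a stated time of 24 h, tested at 10 uM; on this read-out higher numbers stand for more inhibition at the one concentration tested (going by the name of the read-out) and lower numbers for less inhibition
compound 2 `CC(C)=CCC/C(C)=C/CC1Cc2c(OC(=O)Nc3ccc(F)cc3F)cc(=O)n(CCCO)c2CC1(C)C`, giving 15.6% in this assay

Among the measured compounds shown here, compound 2 stands highest of the two numbers in this assay, and its only neighbour is compound 1, set apart from it by the step of a number 15.6 percentage points higher from compound 1 to compound 2 (beyond the scatter), which exchanges the whole group on the ring oxygen.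

Compound 3 `CC(C)=CCC/C(C)=C/CC1Cc2c(OC(=O)Nc3ccc(Cl)cc3)cc(=O)n(CCCO)c2CC1(C)C` differs from compound 2 by 4-chlorophenyl in place of 2,4-difluorophenyl on an amide-type nitrogen. For the measured compounds named here, no measured step touches the ring on the amide-type nitrogen: the one step that exists, a number 15.6 percentage points higher from compound 1 to compound 2 (beyond the scatter), replaces the entire substituent on the oxygen and so does not bear on an exchange of one halogenated phenyl for another. With nothing to lean on, the step of a number 1.4 percentage points higher from compound 2 to compound 3 (within the scatter) is expected to stay within the scatter, in either direction. Compound 3 is therefore estimated to give 17% in this assay, with a range from 0% to 38%.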

Compound 3, a percentage reported as inhibition, at one concentration (the size of the read-out at that concentration, not a potency): 4.3%
Beside the measured number, compound 3's estimate is 12.7 percentage points above it; measured number inside the range.
By their numbers in this assay, from the lowest: compounds 1 and 3 (each within the scatter of the next); then compound 2.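

In this assay, among the compounds shown here, the exchange of 2,4-difluorophenyl for 4-chlorophenyl on the amide-type nitrogen brings a number 11.3 percentage points lower from compound 2 to compound 3 (beyond the scatter) and is the first measured change at this position, so the halogenated phenyl ring on that nitrogen does affect the read-out. The carbamoyl group on the ring oxygen therefore does not by itself bring a gain: replacing 3-(4-methoxyphenoxy)propyl with (4-chlorophenyl)carbamoyl gives a number 4.3 percentage points higher from compound 1 to compound 3 (within the scatter) and leaves the two compounds unseparated, unlike the (2,4-difluorophenyl)carbamoyl group of compound 2. Nothing available explains this difference between the two rings.

The compounds shown leave open whether the halogen or the substitution pattern matters, since 4-chlorophenyl and 2,4-difluorophenyl differ in both. A 4-fluorophenyl, 2,4-dichlorophenyl or unsubstituted phenyl group on the same nitrogen would separate these two possibilities.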